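This account rests on a few compounds, and the source may have more. Where it says the series, first, only, none or still open, it means among the compounds named here.

The structures under comparison share one core, and they differ only in the group attached to the carbonyl carbon and in the substituents on the aromatic ring carried there. Compound 1 `COc1ccc(C(=O)/C=C/c2cc(-c3cc(OC)c(OC)c(OC)c3)n[nH]2)cc1OC` and compound 2 `COc1ccc(C(=O)/C=C/c2cc(-c3cc(OC)c(OC)c(OC)c3)n[nH]2)cc1` have both been tested in a functional assay on T47D cells (Homo sapiens) for cytotoxicity, read by sulforhodamine B assay, with a stated time of 48 h, tested at 10 uM (a lower number here means a stronger effect, a higher number a weaker effect of the compound at the concentration tested), where compound 1 gives -42% and compound 2 gives 1%. Within the data shown here, the one step measured so far, a number 43 percentage points higher from compound 1 to compound 2 (beyond the scatter), rests on hydrogen in place of methoxy on an aromatic carbon. Among the two numbers recorded, compound 2 therefore stands as the higher one, the weaker effect.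

Compound 3 `COc1cc(-c2cc(/C=C/C(=O)c3ccc(F)c(F)c3)[nH]n2)cc(OC)c1OC` has not yet been measured. It differs from compound 2 by 3,4-difluorophenyl in place of 4-methoxyphenyl on a carbonyl carbon. Among the measured compounds shown here, no measured step covers an exchange of this kind: the only step known concerns the removal of a methoxy, not the entry of fluorine, so it bears on the new change only loosely and gives no direction with confidence. The expected step from compound 2 to compound 3 is therefore a number 4 percentage points higher from compound 2 to compound 3 (within the scatter), small and within the scatter. For compound 3 the estimated value in this assay is 5%, with a likely range from -30% to 35%.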

Compound 3, a percentage reported as activity, at one concentration (the size of the read-out at that concentration, not a potency): 9%
The estimate for compound 3 lay 4 percentage points below the measured number; measured number inside the range.
By their numbers in this assay, from the lowest: compound 1; then compounds 2 and 3 (each within the scatter of the next).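

In this assay, among these compounds, the exchange of 4-methoxyphenyl for 3,4-difluorophenyl on the carbonyl carbon gives a number 8 percentage points higher from compound 2 to compound 3 (within the scatter) and so leaves compound 2 and compound 3 indistinguishable, even though two fluorines have replaced the single methoxy group. Set against 3,4-dimethoxyphenyl, the same 3,4-difluorophenyl gives a number 51 percentage points higher from compound 1 to compound 3 (beyond the scatter) and thus a large loss of effect, so among these three compounds only the ring with two methoxy groups goes with the stronger effect, and neither of the other two rings matches it. Nothing available explains why these groups sort this way.

Still open, on these data alone, is whether the stronger effect needs methoxy groups specifically, since a 3,4-diethoxyphenyl or a 3,4-dichlorophenyl on the carbonyl carbon could show whether it would side with compound 1 or with compound 2 and compound 3. An unsubstituted phenyl or a ring carrying a dimethylamino group would also help to show how much this position depends on its substituents, and the single concentration used here gives no potency for any of the three compounds.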